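A few compounds are considered here, and "the series" means these few. Any claim that something is new, unique, unknown or untested is made for them only; others in the source may bear on it.

Measured compounds:
compound 1 `CC(=O)N1N=C(Nc2nc3ccccc3s2)CC1c1ccc(Cl)cc1` — 209 umol/kg
compound 2 `COc1ccc(C2CC(Nc3nc4ccc([N+](=O)[O-])cc4s3)=NN2C(C)=O)cc1O` — 178 umol/kg
compound 3 `CC(=O)N1N=C(Nc2nc3ccc(Cl)cc3s2)CC1c1ccc(O)cc1` — 106 umol/kg

In a functional assay on the whole organism (Hindlimb, strain albino) with Mus musculus as the target, in the maximal electroshock model, with a stated time of 0.5 h (a higher number here means that more compound is needed for the effect, a lower number that less compound is needed), compound 1 gives the highest of the three numbers, yet its gaps to compound 2 and to compound 3 both lie within the scatter, so no order among the three compounds can be read from these values.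

Compound 4 `CC(=O)N1N=C(Nc2nc3ccccc3s2)CC1c1ccccc1` differs from compound 1 by hydrogen in place of chloro on an aromatic carbon. Going by the values given here, no measured pair in this set carries that change, so its effect cannot be taken from the data. The expectation is a step that stays within the scatter, if anything toward a higher number, a 1.2-fold higher number from compound 1 to compound 4 (0.08 log units; within the scatter). Compound 4 is therefore expected to give about 250 umol/kg in this assay, with a range from 120 umol/kg to 520 umol/kg.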

Compound 4, dose for half-maximal effect: 315 umol/kg
Compound 4: the middle estimate sits 1.3-fold (0.10 log units) below what was measured, and the stated range covers the measured number.
By their numbers in this assay, from the lowest: compounds 3, 2, 1 and 4 (each within the scatter of the next, the first and the last beyond it).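

In this assay the change from 4-chlorophenyl to phenyl gives the first step read in one place in this series: a 1.5-fold higher number from compound 1 to compound 4 (0.18 log units; within the scatter) and no more. On this aromatic carbon, therefore, the chloro is not shown to matter, since hydrogen in its place stays within the scatter. Nothing at hand explains this step.

Still open, from the compounds shown here alone, is whether an amine or a carboxylic acid at this place would move the number beyond the scatter. Also open, going by these compounds, is whether the step holds when the shared core carries a further chloro.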